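Adding a cyano group to compound 3

This account rests on a few compounds, and the source may have more. Where it says the series, first, only, none or still open, it means among the compounds named here.

In an ADME assay on HUVEC cells (Homo sapiens) for inhibition, read by CCK-8 assay, with a stated time of 24 h, in the presence of a further agent that is not named here (on this read-out lower numbers stand for stronger inhibition and higher numbers for weaker inhibition), compound 3 `O=C1Nc2ccc(F)cc2C1=Cc1ccc(-c2cn(-c3ccccc3)nn2)cc1` gives 13700 nM and compound 1 `O=C1Nc2ccccc2/C1=C/c1ccc(-c2cn(-c3ccc(F)cc3)nn2)cc1` gives 14700 nM, so these two values lie within the scatter of each other. Compound 2 `N#Cc1cccc(-n2cc(-c3ccc(/C=C4\C(=O)Nc5ccccc54)cc3)nn2)c1` gives > 20000 nM, which is a limit of the assay and not a number.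

Compound 4 `N#Cc1ccccc1-n1cc(-c2ccc(C=C3C(=O)Nc4ccc(F)cc43)cc2)nn1` differs from compound 3 by cyano in place of hydrogen on an aromatic carbon, ortho to a large group, which reads as phenyl to 2-cyanophenyl. Going by the values given here, only one measured step bears on this change, and only loosely: an at least 1.3-fold higher number from compound 1 to compound 2 (0.13 log units; that floor lies within the scatter). That step also introduces a cyano group, but as 3-cyanophenyl replacing 4-fluorophenyl, and its size is known only as a floor within the scatter. A small move towards a higher number, meaning weaker inhibition, is therefore expected, and it may not exceed the scatter. The expected change is a 1.4-fold higher number from compound 3 to compound 4 (0.14 log units; within the scatter). For compound 4 the estimate is 19000 nM, with an expected range of 10000 nM to 35000 nM.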

Compound 4, half-maximal inhibitory concentration: > 20000 nM
Compound 4 was reported as a limit; the forecaster's own chance of this, stated with the estimate: 45%; at least 1.0-fold (0.02 log units) between middle value and limit.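

With the rest of compound 3 held fixed, cyano in place of hydrogen on an aromatic carbon, ortho to a large group, gives an at least 1.4-fold higher number from compound 3 to compound 4 (0.16 log units; that floor lies within the scatter) in this assay, and this step isolates the cyano group where the earlier step also changed the fluorine. The value of compound 4 is a limit of the assay and not a number, so only the floor of this step is known, and no rise beyond the scatter is shown. Compound 2 and compound 4, the two nitriles shown, both stand at the same limit: the limit of > 20000 nM in this assay, at which 2 of the 4 values shown sit.

From the compounds shown here alone, how far compound 4 lies past that limit stays open. Also open, going by these compounds, is whether an amine or a carboxylic acid, ortho to a large group on the same ring, would give a value that can be read as a number.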